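The source may report more compounds than this note shows. Statements on the series, on what has been measured and on what is new or still open speak of the compounds shown alone.

Three compounds share one core in this account, and they were examined in an ADME assay on Vero cells (Chlorocebus sabaeus) for cytotoxicity, with a stated time of 72 h; a higher number here means a weaker inhibitor, a lower number a stronger inhibitor. For compound 1 (`CCOC(=O)c1cc(/C=C/c2ccccc2)on1`) the record reads "not determined" (no result reported), so it offers no comparison. Compound 2 (`CCOC(=O)c1cc(/C=C/c2cccc(C(F)(F)F)c2)on1`) gives > 128000 nM, which is a limit of the assay and not a number. Among the compounds with values here, compound 2 therefore has no exact position on the scale, and the only evidence available is the limit of > 128000 nM in this assay, at which 1 of the 2 values shown sits.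

Compound 3 (`CCOC(=O)c1cc(/C=C/c2cccc(C(C)C)c2)on1`) has not yet been measured. It carries isopropyl in place of trifluoromethyl on an aromatic carbon, meta to a large group, and the change is counted as isopropyl in place of trifluoromethyl on an aromatic carbon. Within the data shown here, no measured pair of compounds shows what such a swap does in this assay, so the expectation rests on the limit reached by compound 2 at > 128000 nM. No step beyond the usual scatter is expected, and a further limit would be no surprise. The expected change is an at least 1.1-fold lower number from compound 2 to compound 3 (0.06 log units; that floor lies within the scatter). The estimate for compound 3 is 110000 nM, with an expected range from 45000 nM to 256000 nM.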

Compound 3, half-maximal inhibitory concentration: > 128000 nM
Compound 3 gave a limit, no number (the forecaster's own chance of this, stated with the estimate: 65%); middle value at least 1.1-fold (0.06 log units) away from the limit.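

In this assay compound 3 gives > 128000 nM, which is a limit of the assay and not a number. Compound 2 also stands at a limit, so no step can be read between compound 2 and compound 3: the limit of > 128000 nM in this assay, at which 2 of the 3 values shown sit.

The compounds shown leave open whether isopropyl in place of trifluoromethyl changes the result in this assay at all.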